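The source may hold more compounds than are shown below. What is called first, only, known or untested is meant among the compounds shown, and "the series" means these compounds.

In a functional assay on Caco-2 cells (Homo sapiens) for cytotoxicity, with a stated time of 48 h (a lower number here means a stronger inhibitor, a higher number a weaker inhibitor), three compounds have been measured so far. Compound 1 (`COc1cc(O)c(C(=O)/C=C/c2ccc(F)cc2)c(OC)c1`) gives 9200 nM, compound 2 (`COc1cc(OC)c(C(=O)/C=C/c2ccccc2)c(OC)c1`) gives 5800 nM and compound 3 (`COc1cc(O)c(C(=O)/C=C/c2ccccc2OC)c(OC)c1`) gives 10000 nM. Compound 2 stands within the scatter of both of the others, so these numbers set no order among the three compounds.

Compound 4 (`COc1cc(OC)c(C(=O)/C=C/c2ccc(Br)cc2)c(OC)c1`) has not yet been measured. It departs from compound 2 in one place, as bromo in place of hydrogen on an aromatic carbon shows: bromo in place of hydrogen on an aromatic carbon, para to a large group. Going by the values given here, no pair of measured compounds differs in only one place, so the data offer no direct guide to the effect of this change in this assay. Among the compounds with values here, the only guide is the narrow band of values, with compound 2 at 5800 nM and compound 3 at 10000 nM still within the scatter of each other.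

On that basis, no shift beyond the scatter is expected, and any movement is expected to be slight and towards a lower number. The expected change is a 1.2-fold lower number from compound 2 to compound 4 (0.06 log units; within the scatter). For compound 4, the estimated value is 5000 nM, with an expected range from 2300 nM to 11000 nM.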

Compound 4, half-maximal inhibitory concentration: 6800 nM
Estimate against measurement, compound 4: 1.4-fold (0.13 log units) below, and the stated range covers the measured number.
By their numbers in this assay, from the lowest: compounds 2, 4, 1 and 3 (each within the scatter of the next).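

In this assay, this is the first single change that can be read directly among the compounds shown: bromo in place of hydrogen on an aromatic carbon, para to a large group, gives a 1.2-fold higher number from compound 2 to compound 4 (0.07 log units; within the scatter). The change from phenyl to 4-bromophenyl adds one heavy atom, and this position accepts that bromine with no difference that can be told apart from the scatter of repeated measurements. Nothing available bears on the reason for this result.

This one step covers only a single halogen at a single position, so it cannot show whether the position would stay as unresponsive to a different kind of group, such as an amine, a carboxylic acid or a longer alkyl chain. Compound 1 also carries a halogen, a fluoro group, but it differs from compound 4 in more than one place, which leaves open how the two halogens compare on an otherwise identical core.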